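This account rests on a few compounds, and the source may have more. Where it says the series, first, only, none or still open, it means among the compounds named here.

Compound 1, whose structure is `Cc1nc(C(=O)Nc2ccc(Cl)c(-c3nnc4c(Cl)cccn34)c2)cs1`, carries an amide on its shared core, and in a functional assay on T47D cells (Homo sapiens) for antiproliferative activity, read by MTT assay, with a stated time of 72 h (on this read-out higher numbers stand for weaker inhibition and lower numbers for stronger inhibition), compound 1 gives > 100000 nM, a value that is a limit of the assay and not a number. Compound 1 thus sits at the limit of > 100000 nM in this assay, at which 1 of the 2 values shown sits, so where it stands among the values shown can only be given as that limit. Compound 2, with the structure `O=C(Nc1ccc(Cl)c(-c2nnc3c(Cl)cccn23)c1)c1ccc(C(F)(F)F)cc1F`, places a substituted benzene ring on the same carbonyl, and in this assay compound 2 gives 70800 nM, a measurable though weak inhibition.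

Compound 3, structure `Cc1cc(Cl)ccc1C(=O)Nc1ccc(Cl)c(-c2nnc3c(Cl)cccn23)c1`, has not yet been tested. It differs from compound 1 by 4-chloro-2-methylphenyl in place of 2-methyl-1,3-thiazol-4-yl on a carbonyl carbon. Among the measured compounds shown here, no measured pair of compounds mirrors this change, so its effect is open; since compound 1 is known only as a limit, the step from compound 1 to compound 3 can be expected, at most, to reach into the measurable range, with the estimated step being an at least 1.6-fold lower number from compound 1 to compound 3 (0.22 log units; that floor lies within the scatter). On that basis compound 3 is expected to give about 60000 nM in this assay, within a range from 15000 nM to 200000 nM.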

Compound 3, half-maximal inhibitory concentration: > 100000 nM
Compound 3: a limit, no number; the forecaster's own chance of this, stated with the estimate: 40%; middle value at least 1.6-fold (0.22 log units) away from the limit.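

No step can be read between compound 1 and compound 3, as the values of both are limits of the assay and not numbers: the limit of > 100000 nM in this assay, at which 2 of the 3 values shown sit.

On these data alone, whether 4-chloro-2-methylphenyl in place of 2-methyl-1,3-thiazol-4-yl on a carbonyl carbon changes the inhibition in this assay at all, and by how much, stays open.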